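A few compounds are considered here, and "the series" means these few. Any claim that something is new, unique, unknown or untested is made for them only; others in the source may bear on it.

In a functional assay on KB cells (Homo sapiens) for cytotoxicity, read by MTT assay, with a stated time of 72 h (a lower number here means that less compound is needed, a higher number that more compound is needed for the effect), compound 1 `O=C1/C(=C\c2c(Cl)cccc2Cl)c2ccccc2N1c1c(Cl)cccc1Cl` gives 50 ug/mL, the highest number among the three compounds measured. Compound 2 `O=C1/C(=C\c2ccc(O)cc2)c2ccccc2N1c1c(Cl)cccc1Cl` gives 2 ug/mL in this assay, and compound 3 `O=C1/C(=C\c2ccccc2[N+](=O)[O-])c2ccccc2N1c1c(Cl)cccc1Cl` gives 1 ug/mL. Both of these compounds keep the shared core of compound 1 and differ from it only in the group on the double-bonded chain carbon bound to a double-bonded ring carbon: the exchange gives a 25-fold lower number from compound 1 to compound 2 (1.40 log units; beyond the scatter) and a 50-fold lower number from compound 1 to compound 3 (1.70 log units; beyond the scatter), while the pair of compounds 2 and 3 shows a 2.0-fold lower number from compound 2 to compound 3 (0.30 log units; within the scatter).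

Compound 4 `O=C1/C(=C\c2cccc(Cl)c2)c2ccccc2N1c1c(Cl)cccc1Cl` changes the same group of compound 1: 3-chlorophenyl in place of 2,6-dichlorophenyl on a double-bonded chain carbon bound to a double-bonded ring carbon. The two measured steps that bear on this, from compound 1 to compound 2 and from compound 1 to compound 3, were both large and in the same direction, though the entering groups there were not chlorophenyl. The expectation is therefore a lower number for compound 4 than for compound 1, but of a more modest size, estimated as a 5.0-fold lower number from compound 1 to compound 4 (0.70 log units; beyond the scatter). Compound 4 is thus expected to give about 10 ug/mL in this assay, with a range from 3 ug/mL to 40 ug/mL.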

Compound 4, concentration for half-maximal effect: 2 ug/mL
Estimate against measurement, compound 4: 5.0-fold (0.70 log units) above, outside the stated range (below it).
By their numbers in this assay, from the lowest: compounds 3, 2 and 4 (each within the scatter of the next); then compound 1.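

With 3-chlorophenyl in place of 2,6-dichlorophenyl, this assay gives a 25-fold lower number from compound 1 to compound 4 (1.40 log units; beyond the scatter), so the large step at this position does not depend on a hydroxyl or nitro group, and a chlorine on the entering phenyl does not by itself bring back the high number of compound 1. The new group joins the other two entering groups, with a 2.0-fold higher number from compound 3 to compound 4 (0.30 log units; within the scatter) and no change at the digits printed from compound 2 to compound 4 (within the scatter), so the three groups cannot be ordered here. Nothing available explains why 2,6-dichlorophenyl stands apart from them.

On these data alone, it remains open whether 2-chlorophenyl or 4-chlorophenyl would stay with compound 4 or move toward compound 1. Also open, as far as these compounds go, is how an amine or a carboxylic acid on this phenyl, or a longer chain in its place, would read in this assay.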